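The compounds below may be only part of what the source reports. "The series", "measured", "known", "first", "only" and "open" are said of these compounds alone.

Compound 1 `CN(C)CC[C@H](CSc1ccccc1)Nc1ccc(S(=O)(=O)NC(=O)c2ccc(N3CCN(Cc4ccccc4-c4ccc(Cl)cc4)CC3)cc2)cc1C(F)(F)F`: 2460 nM
Compound 2 `CN(C)CC[C@H](CSc1ccccc1)Nc1ccc(S(=O)(=O)NC(=O)c2ccc(N3CCN(Cc4ccccc4-c4ccc(Cl)cc4)CC3)cc2)cc1S(C)(=O)=O`: 34900 nM
Compound 3 `CN(C)CC[C@H](CSc1ccccc1)Nc1ccc(S(=O)(=O)NC(=O)c2ccc(N3CCN(CC4=C(c5ccc(Cl)cc5)CCOC4)CC3)cc2)cc1[N+](=O)[O-]`: 266 nM

In a functional assay on NCI-H146 cells (Homo sapiens) for cytotoxicity, with a stated time of 48 h, in the presence of a further agent that is not named here (a lower number here means that less compound is needed, a higher number that more compound is needed for the effect), compound 2 has the highest of these three numbers, at 34900 nM. The unmeasured compound 4 `CN(C)CC[C@H](CSc1ccccc1)Nc1ccc(S(=O)(=O)NC(=O)c2ccc(N3CCN(Cc4ccccc4-c4ccc(Cl)cc4)CC3)cc2)cc1S(=O)(=O)C(F)(F)F` differs from compound 2 in a single place: trifluoromethyl in place of methyl on a sulfonyl sulfur. Here trifluoromethyl takes the place of methyl on a sulfonyl sulfur, which turns methylsulfonyl into (trifluoromethyl)sulfonyl.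

Within the data shown here, only one measured step involves the methylsulfonyl group: a 14-fold higher number from compound 1 to compound 2 (1.15 log units; beyond the scatter), where methylsulfonyl took the place of trifluoromethyl on an aromatic carbon. That step was large, but it is not the same change, so it offers only a rough guide. Compound 4 keeps the sulfonyl of compound 2 and carries a trifluoromethyl as compound 1 does. A sizeable move towards a lower number is therefore expected, with an estimated step of a 23-fold lower number from compound 2 to compound 4 (1.37 log units; beyond the scatter). The expected value for compound 4 is 1500 nM, with an estimated range from 200 nM to 9000 nM.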

Compound 4, half-maximal effective concentration: 39.4 nM
Compound 4: middle estimate off by 38-fold (1.58 log units), on the high side; measured number below the stated range.
By their numbers in this assay, from the lowest: compound 4; then compound 3; then compound 1; then compound 2.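

In this assay, exchanging only the methyl on the sulfonyl sulfur for trifluoromethyl gives an 890-fold lower number from compound 2 to compound 4 (2.95 log units; beyond the scatter), so the sulfonyl alone does not set the number here: what it carries matters greatly. The earlier step, a 14-fold higher number from compound 1 to compound 2 (1.15 log units; beyond the scatter), could have suggested that a sulfonyl at this place simply raises the number, but a 62-fold lower number from compound 1 to compound 4 (1.80 log units; beyond the scatter) shows that (trifluoromethyl)sulfonyl goes the other way and ends well below plain trifluoromethyl. The data shown offer no explanation for why this small exchange has so large an effect.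

As far as these compounds go, it remains open whether other groups on the sulfonyl sulfur, such as an ethyl chain or an amine, would fall nearer compound 2 or compound 4. Compound 3 differs from compound 4 in more than one place, so the effect of its nitro group cannot be read against (trifluoromethyl)sulfonyl.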